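The source may report more compounds than this note shows. Statements on the series, on what has been measured and on what is new or still open speak of the compounds shown alone.

Measured: compound 1 `CCOC(=O)c1ccc(-c2nn(Cc3cccc(F)c3)c3ccccc23)cc1`, compound 2 `CCOC(=O)c1ccc(-c2nn(Cc3ccc(F)cc3)c3ccccc23)cc1`.

In a functional assay on cells (Platelet, Homo sapiens) for inhibition (on this read-out higher numbers stand for weaker inhibition and lower numbers for stronger inhibition), compound 1 gives > 10000 nM, a limit of the assay rather than a number. Compound 2 gives > 10000 nM, likewise a limit. The step that the two limits leave unreadable from compound 1 to compound 2 shows only that both sit at the limit of > 10000 nM in this assay, at which 2 of the 2 values shown sit. Compound 3 `CCCCn1nc(-c2ccc(C(=O)OCC)cc2)c2ccccc21` is not yet measured and differs from compound 1 by propyl in place of 3-fluorophenyl on a saturated chain carbon bound to an aromatic nitrogen. No measured step bears on this change, so neither direction nor size beyond the scatter can be read from the numbers shown. Compound 3 is expected at 15000 nM, range 3000 nM to 60000 nM, most likely again a limit. This expectation means the step that the limit leaves unreadable from compound 1 to compound 3.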

Compound 3, half-maximal inhibitory concentration: > 10000 nM
Compound 3 was reported as a limit (the forecaster's own chance of this, stated with the estimate: 85%); the middle value does not contradict the limit.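

No step among compound 1, compound 2 and compound 3 can be read in this assay, because all three stand at the same limit: the limit of > 10000 nM in this assay, at which 3 of the 3 values shown sit.

On these data alone, whether any group on a saturated chain carbon bound to an aromatic nitrogen gives a measurable inhibition value remains open.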